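Fluoro to Hydrogen on the Shared Core

This account rests on a few compounds, and the source may have more. Where it says the series, first, only, none or still open, it means among the compounds named here.

Compound 1 `Fc1ccc(/C=C/c2nnc(-c3ccc4c(c3)OCCO4)o2)cc1` was tested in an ADME assay on HUVEC cells (Homo sapiens) for cytotoxicity, read by MTT assay, with a stated time of 24 h (on this read-out lower numbers stand for higher toxicity in this test and higher numbers for lower toxicity in this test), where compound 1 gives 325000 nM. For the measured compounds named here, only one other number is available: compound 2 `COc1ccc(/C=C/c2nnc(-c3ccc4c(c3)OCCO4)o2)cc1` gives 312000 nM in this assay, and the step of a 1.0-fold lower number from compound 1 to compound 2 (0.02 log units; within the scatter) shows that the two compounds cannot be told apart on this read-out. Compound 3 `C(=C/c1nnc(-c2ccc3c(c2)OCCO3)o1)\c1ccccc1` has not yet been measured. It differs from compound 1 by hydrogen in place of fluoro on an aromatic carbon. Going by the values given here, the one measured step that bears on this position is the exchange of the same fluoro for methoxy between compound 1 and compound 2, which left the read-out essentially unchanged. On that basis no step beyond the scatter is expected in this assay, in either direction. For compound 3, the expected outcome is a 1.0-fold lower number from compound 1 to compound 3 (0.01 log units; within the scatter). Compound 3 is therefore estimated at 320000 nM, with a range of 160000 nM to 640000 nM.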

Compound 3, half-maximal cytotoxic concentration: 209000 nM
Compound 3: middle estimate off by 1.5-fold (0.19 log units), on the high side; the measured number falls inside the stated range.
By their numbers in this assay, from the lowest: compounds 3, 2 and 1 (each within the scatter of the next).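

Hydrogen in place of fluoro gives a 1.6-fold lower number from compound 1 to compound 3 (0.19 log units; within the scatter) and hydrogen in place of methoxy gives a 1.5-fold lower number from compound 2 to compound 3 (0.17 log units; within the scatter) on this aromatic carbon. The earlier pair showed only one substituent exchanged for another, whereas compound 3 shows the ring with no substituent at this place, the change from 4-fluorophenyl to phenyl. In this assay hydrogen, fluoro and methoxy at this place therefore cannot be told apart, so among these three compounds the read-out does not depend on a substituent being present there. Nothing at hand bears on why these numbers stay so close.

Still open, from the compounds shown here alone, is whether an amine, a carboxylic acid or a longer chain at this place would move the number beyond the scatter. The compounds shown also leave open whether changes elsewhere on the shared core would do so.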